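A few compounds are considered here, and "the series" means these few. Any claim that something is new, unique, unknown or untested is made for them only; others in the source may bear on it.

Four compounds are compared here: compound 1 `CC(C)(C)c1ccc(CN(Cc2cccc(CCC(=O)O)c2)S(=O)(=O)c2ccc(Cl)cc2)cc1`, compound 2 `CCCCC(O)c1ccc(CN(CCCCCCC(=O)O)S(C)(=O)=O)cc1`, compound 3 `CCCCCC(O)CCCN(CCCCCC(=O)O)S(C)(=O)=O` and the not yet measured compound 4 `CS(=O)(=O)N(CCCCCCC(=O)O)Cc1ccc(-c2ccccc2)cc1`. In an assay on HEK293 cells for inhibition of prostaglandin E2 receptor EP2 subtype (Rattus norvegicus) (on this read-out higher numbers stand for weaker inhibition and lower numbers for stronger inhibition), compound 1 reaches only a limit of the assay, > 3200 nM. Compound 2 gives 502 nM in this assay, the lower of the two plain numbers; compound 3 gives 910 nM, which lies within the usual scatter of compound 2, so the two cannot be ranked. Compound 4 arises from compound 2 by one change: phenyl in place of 1-hydroxypentyl on an aromatic carbon. Going by the values given here, no measured pair isolates this change, so the expected step in this assay is a modest weakening, of a size the scatter could largely hide. Compound 4 is therefore expected near 1000 nM, within 300 nM to 4000 nM. This expectation means an estimated step of a 2.0-fold higher number from compound 2 to compound 4 (0.30 log units; within the scatter).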

Compound 4, half-maximal inhibitory concentration: 289 nM
The estimate for compound 4 lay 3.5-fold (0.54 log units) above the measured number; the whole stated range lies above it.
By their numbers in this assay, from the lowest: compounds 4, 2 and 3 (each within the scatter of the next, the first and the last beyond it). At a limit, above all of these: compound 1.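

Replacing 1-hydroxypentyl with phenyl on this aromatic carbon gives a 1.7-fold lower number from compound 2 to compound 4 (0.24 log units; within the scatter) in this assay. This place on the ring therefore accepts either a flexible-looking open chain carrying a hydrogen-bond donor and acceptor or a six-membered aromatic ring of carbon only with neither, and the two cannot be ranked. Nothing measured here explains why the two groups read alike. The compounds shown leave open whether the hydroxyl group alone matters at this place. A plain pentyl chain or a pyridine ring there would help to separate the contribution of the hydroxyl group from that of the ring.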